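A few compounds are considered here, and "the series" means these few. Any claim that something is new, unique, unknown or untested is made for them only; others in the source may bear on it.

Compound 1, `OC[C@H]1O[C@@H](n2cnc3c(NCc4cccc(C(F)(F)F)c4)ncnc32)[C@H](O)[C@@H]1O`, in a functional assay on K562 cells (Homo sapiens) for antiproliferative activity, with a stated time of 72 h (on this read-out higher numbers stand for weaker inhibition and lower numbers for stronger inhibition), gives > 166000 nM, a limit of the assay rather than a number. Compound 2, `OC[C@H]1O[C@@H](n2cnc3c(NCc4ccc(C(F)(F)F)cc4)ncnc32)[C@H](O)[C@@H]1O`, in this assay gives > 166000 nM, again a limit. Compound 3, `OC[C@H]1O[C@@H](n2cnc3c(NCc4cccc(OC(F)(F)F)c4)ncnc32)[C@H](O)[C@@H]1O`, in this assay gives > 166000 nM, also a limit.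

Compound 2 differs from compound 1 in its core: 4-(trifluoromethyl)phenyl in place of 3-(trifluoromethyl)phenyl on a saturated chain carbon bound to a nitrogen on an aromatic ring. That step, a step that the two limits leave unreadable from compound 1 to compound 2, cannot be sized. The change trifluoromethoxy in place of trifluoromethyl on an aromatic carbon gives a step that the two limits leave unreadable from compound 1 to compound 3, equally unreadable. Compound 4, `OC[C@H]1O[C@@H](n2cnc3c(NCc4ccc(OC(F)(F)F)cc4)ncnc32)[C@H](O)[C@@H]1O`, is not yet measured; it differs from compound 2 by trifluoromethoxy in place of trifluoromethyl on an aromatic carbon, the same kind of change as that from compound 1 to compound 3, here para to a large group rather than meta to a large group. Since (the limit of > 166000 nM in this assay, at which 3 of the 3 values shown sit), the step from compound 2 to compound 4 is expected to be a step that the limit leaves unreadable from compound 2 to compound 4, again most likely only a limit. Compound 4 is therefore estimated at 300000 nM in this assay.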

Compound 4, half-maximal inhibitory concentration: > 166000 nM
Compound 4: a limit, no number (the forecaster's own chance of this, stated with the estimate: 90%); the middle value does not contradict the limit.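

Compound 4 gives > 166000 nM in this assay, a limit and not a number. Compound 2 also sits at a limit, so the step between compound 2 and compound 4 cannot be read. The compounds shown leave open whether trifluoromethoxy in place of trifluoromethyl changes the activity at all.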